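The source may report more compounds than this note shows. Statements on the series, on what has been measured and on what is new or still open speak of the compounds shown alone.

Measured in a toxicity assay on HaCaT cells (Homo sapiens) for cytotoxicity, read by CCK-8 assay, with a stated time of 24 h; on this read-out lower numbers stand for higher toxicity in this test and higher numbers for lower toxicity in this test:
- Compound 1 `COc1ccccc1Oc1c(N)nc(-c2cccc(C)c2)nc1Cl`: 11200 nM
- Compound 2 `COc1ccccc1Oc1c(N)nc(-c2ccc(C)cc2)nc1Cl`: 6300 nM
- Compound 3 `COc1cccc(-c2nc(N)c(Oc3ccccc3OC)c(Cl)n2)c1`: 14000 nM

Going by the values given here, compound 2 stands at the low end of these numbers, though only one of its two steps clears the scatter: a 1.8-fold lower number from compound 1 to compound 2 (0.25 log units; within the scatter), and a 2.2-fold higher number from compound 2 to compound 3 (0.35 log units; beyond the scatter). Compound 4 `COc1ccccc1Oc1c(N)nc(-c2cccc(F)c2)nc1Cl` is not yet measured. It differs from compound 2 at one place: 3-fluorophenyl in place of 4-methylphenyl on an aromatic carbon. Its 3-fluorophenyl replaces 4-methylphenyl. Among the compounds with values here, no fluorinated compound has been tested, so the closest guides are the 3-methylphenyl of compound 1 and the 3-methoxyphenyl of compound 3, and swapping between those two gave only a 1.3-fold higher number from compound 1 to compound 3 (0.10 log units; within the scatter). A small step is therefore expected: a 1.6-fold higher number from compound 2 to compound 4 (0.20 log units; within the scatter). The estimate for compound 4 is 10000 nM, with an expected range of 5000 nM to 20000 nM.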

Compound 4, half-maximal cytotoxic concentration: 17000 nM
For compound 4 the middle estimate is 1.7-fold (0.23 log units) below the measured one; measured number inside the range.
By their numbers in this assay, from the lowest: compounds 2, 1, 3 and 4 (each within the scatter of the next, the first and the last beyond it).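

In this assay, the 3-fluorophenyl group of compound 4 brings fluorine into this position, and replacing the 4-methylphenyl group of compound 2 gives a step that clears the scatter (a 2.7-fold higher number from compound 2 to compound 4 (0.43 log units; beyond the scatter)). The other two steps do not (a 1.2-fold higher number from compound 3 to compound 4 (0.08 log units; within the scatter); a 1.5-fold higher number from compound 1 to compound 4 (0.18 log units; within the scatter)), so 3-fluorophenyl, 3-methylphenyl and 3-methoxyphenyl cannot be told apart here. Nothing measured here explains the difference from compound 2.

Going by these compounds, whether a 4-fluorophenyl group would resemble the 4-methylphenyl group of compound 2 remains open. So does the effect of a phenyl ring carrying an amine or a carboxylic acid.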